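A few compounds are considered here, and "the series" means these few. Any claim that something is new, unique, unknown or untested is made for them only; others in the source may bear on it.

Compound 1 `Cc1ccc(S(=O)(=O)Oc2cccc(/C=C(\C#N)C(=O)Nc3nnc(-c4ccccc4Cl)s3)c2)cc1`: 55%
Compound 2 `Cc1ccc(S(=O)(=O)Oc2cccc(/C=C(\C#N)C(=O)Nc3nnc(-c4cccs4)s3)c2)cc1`: 43%

Going by the values given here, in an ADME assay on HEK-293T cells (Homo sapiens) for inhibition, read by CCK-8 assay, with a stated time of 48 h, tested at 20 uM (a lower number here means less inhibition of growth, a higher number more inhibition of growth at the concentration tested), compound 2 gives 43%, the lower of the two numbers measured so far. The next molecule, compound 3 `N#C/C(=C\c1cccc(OS(=O)(=O)c2cccs2)c1)C(=O)Nc1nnc(-c2cccs2)s1`, differs from compound 2 in a single group: thiophen-2-yl in place of 4-methylphenyl on a sulfonyl sulfur. In words, thiophen-2-yl takes the place of 4-methylphenyl on a sulfonyl sulfur.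

Among the compounds with values here, only one measured step bears on this change, and only loosely: a number 12 percentage points lower from compound 1 to compound 2 (beyond the scatter). That step also brought in thiophen-2-yl, but in place of 2-chlorophenyl on an aromatic carbon, so both the group replaced and its place were different. Within the data shown here, no measured pair of compounds differs in the group on the sulfonyl sulfur, so the data give no direct guide here. A single modest downward step offers only a weak hint of direction. The expected change is a number 3 percentage points lower from compound 2 to compound 3 (within the scatter), a small fall that may not clear the usual scatter. Compound 3 is estimated at 40%, with an expected range from 25% to 55%.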

Compound 3, percent growth inhibition at one concentration: 50%
For compound 3 the middle estimate is 10 percentage points below the measured one, within the range that was stated.
By their numbers in this assay, from the lowest: compounds 2, 3 and 1 (each within the scatter of the next, the first and the last beyond it).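

In this assay, going by these compounds alone, this is the first change seen on the sulfonyl sulfur: thiophen-2-yl in place of 4-methylphenyl gives a number 7 percentage points higher from compound 2 to compound 3 (within the scatter), so swapping this six-membered carbon ring for a five-membered aromatic ring with one hetero atom does not move the number clearly at this place. The same incoming group on an aromatic carbon gave a number 12 percentage points lower from compound 1 to compound 2 (beyond the scatter), so the step seen there does not carry over to the sulfonyl sulfur, although the group replaced also differs between the two changes. No measurement here explains either step.

The compounds shown carry only aromatic rings on the sulfonyl sulfur, so it remains open whether a small group such as methyl, or a ring bearing a carboxylic acid, would leave the number just as unchanged. On these data alone, what an amine in place of the oxygen on the aromatic ring would do to growth inhibition also stays open, since that oxygen is the same in all three compounds.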